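This account rests on a few compounds, and the source may have more. Where it says the series, first, only, none or still open, it means among the compounds named here.

Measured so far in a functional assay on K562 cells (Homo sapiens) for cytotoxicity, read by MTT assay; on this read-out higher numbers stand for weaker inhibition and lower numbers for stronger inhibition:
- compound 1 `COc1ccc(/C=C/C(=O)c2ccc(OC)c3c2OC(C)(C)C=C3)cc1OCC=C(C)C`: > 10000 nM, a limit and not a number
- compound 2 `C#CCOc1cc(/C=C/C(=O)c2ccc(OC)c3c2OC(C)(C)C=C3)ccc1OC`: > 10000 nM, a limit and not a number
- compound 3 `COc1ccc(/C=C/C(=O)c2ccc(OC)c3c2OC(C)(C)C=C3)cc1OC(=O)C(C)C`: 570 nM

Within the data shown here, compound 3 holds the only true number here, at 570 nM. Compound 1 and compound 2 both stop at the limit of > 10000 nM in this assay, at which 2 of the 3 values shown sit.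

Compound 4 `COc1ccc(/C=C/C(=O)c2ccc(OC)c3c2OC(C)(C)C=C3)cc1CS(C)(=O)=O` has not been measured yet. It differs from compound 3 in one place: (methylsulfonyl)methyl in place of (isopropylcarbonyl)oxy on an aromatic carbon. The (isopropylcarbonyl)oxy group leaves, and (methylsulfonyl)methyl enters on the same aromatic carbon.

Among the measured compounds shown here, two measured steps bear on this change: an at least 17-fold lower number from compound 1 to compound 3 (1.24 log units; beyond the scatter) and an at least 17-fold lower number from compound 2 to compound 3 (1.24 log units; beyond the scatter). Both are large and beyond the scatter, and each one installs the isopropylcarbonyl group on the oxygen. Compound 4 loses that group, as compound 1 and compound 2 lack it. Neither step, however, involves the entering group, so they guide the direction better than the size.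

In this assay a sizeable move towards a higher number, meaning weaker inhibition, is therefore expected, and the result may turn out to be only a limit. The expected change is an 8.8-fold higher number from compound 3 to compound 4 (0.94 log units; beyond the scatter). The estimate for compound 4 is 5000 nM, with an expected range from 1200 nM to 20000 nM.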

Compound 4, half-maximal inhibitory concentration: 9240 nM
Compound 4: middle estimate off by 1.8-fold (0.27 log units), on the low side, within the range that was stated.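

In this assay, putting (methylsulfonyl)methyl in place of (isopropylcarbonyl)oxy on this aromatic carbon, ortho to a methoxy group, gives a 16-fold higher number from compound 3 to compound 4 (1.21 log units; beyond the scatter). Both groups count 2 hydrogen-bond acceptors and 0 hydrogen-bond donors, so matching those counts at this position is not enough to keep the low number of compound 3, and a group with no oxygen on the ring now has a true value rather than a limit. Set against the propargyloxy and (3-methylbut-2-en-1-yl)oxy groups, the result reads as an at least 1.0-fold lower number from compound 2 to compound 4 (0.03 log units; that floor lies within the scatter) and an at least 1.0-fold lower number from compound 1 to compound 4 (0.03 log units; that floor lies within the scatter), so how far compound 4 sits from either stays unknown, as compound 1 and compound 2 give only a limit and not a number: the limit of > 10000 nM in this assay, at which 2 of the 4 values shown sit.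

The compounds shown leave open which part of the (isopropylcarbonyl)oxy group goes with the low number of compound 3: the oxygen on the ring, the carbonyl or the isopropyl. A hydroxyl, an acetyl ester or an amide on this same carbon would begin to separate these parts.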